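Allyloxy in place of benzyloxy: solubility notes on the series

A few compounds are considered here, and "the series" means these few. Any claim that something is new, unique, unknown or untested is made for them only; others in the source may bear on it.

Compound 1 `CN(C)CCNc1ccnc2cc(OCc3ccc(F)cc3)ccc12` carries a fluoro on an aromatic carbon; in a physicochemical assay for solubility (a lower number here means a less soluble compound, a higher number a more soluble compound), compound 1 gives > 10000 ug/mL, which is a limit of the assay and not a number. Compound 2 `CN(C)CCNc1ccnc2cc(OCc3ccccc3)ccc12` has hydrogen in that place. In this assay compound 2 gives > 10000 ug/mL, again a limit rather than a number. The step that the two limits leave unreadable from compound 1 to compound 2 cannot be sized because of the limit of > 10000 ug/mL in this assay, at which 2 of the 2 values shown sit. Compound 2 thus stands at the limit of what this assay reports, and nothing in the measured pair places it anywhere else.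

Compound 3 `C=CCOc1ccc2c(NCCN(C)C)ccnc2c1` differs from compound 2 by vinyl in place of phenyl on a saturated chain carbon bound to an oxygen on an aromatic ring; cut one bond further out, the change reads benzyl to allyl, benzyloxy to allyloxy. Going by the values given here, no measured step touches this part of the molecule, and the single measured step, being unreadable, offers no size to carry over. The expectation is therefore that compound 3 stays at or past the limit in this assay. With both measured values sitting at the limit, the step that the limit leaves unreadable from compound 2 to compound 3 is expected to be none beyond the scatter. Compound 3 is estimated at 15000 ug/mL, within 5000 ug/mL to 40000 ug/mL, most likely returned as a limit once more.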

Compound 3, solubility: > 10000 ug/mL
Compound 3 was reported as a limit (the forecaster's own chance of this, stated with the estimate: 85%); the middle value does not contradict the limit.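

No step among compound 1, compound 2 and compound 3 can be read in this assay, because all three values are limits and not numbers: the limit of > 10000 ug/mL in this assay, at which 3 of the 3 values shown sit.

The compounds shown leave open what the solubility of any of the three is as a number, and whether benzyloxy and allyloxy differ at all in this read-out.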